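Moving the methyl around the pyridine ether of compound 3

The source may hold more compounds than are shown below. What is called first, only, known or untested is meant among the compounds shown, and "the series" means these compounds.

Measured compounds in a functional assay for agonist activity at Free fatty acid receptor 1 (Homo sapiens), read by FLIPR, in the presence of a further agent that is not named here; a higher number here means that more compound is needed for the effect, a lower number that less compound is needed:
compound 1 `Cc1ccccc1Oc1ccc(CC2SC(=O)NC2=O)cc1`: 124 nM
compound 2 `O=C1NC(=O)C(Cc2ccc(Oc3cccc(Cl)c3)cc2)S1`: 318 nM
compound 3 `Cc1ccc(Oc2ccc(CC3SC(=O)NC3=O)cc2)nc1`: 4470 nM

Compound 3 stands at the highest number of the three, with compound 2 nearest and compound 1 furthest; in this assay compound 3 gives 4470 nM. The two steps that lead to it are both large: a 36-fold higher number from compound 1 to compound 3 (1.56 log units; beyond the scatter) and a 14-fold higher number from compound 2 to compound 3 (1.15 log units; beyond the scatter), while the change between the two phenyl ethers was only modest, a 2.6-fold higher number from compound 1 to compound 2 (0.41 log units; beyond the scatter).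

Compound 4 `Cc1cccnc1Oc1ccc(CC2SC(=O)NC2=O)cc1` keeps every atom of compound 3 and differs only in where the methyl sits on the pyridine: 3-methylpyridin-2-yl in place of 5-methylpyridin-2-yl on an oxygen on an aromatic ring. For the measured compounds named here, no measured step moves a substituent within the pyridine ring, so none bears directly on this change; the only relevant fact is that the one pyridine ether, compound 3, gives the highest number. The step is therefore expected to be small, with compound 4 estimated at 2800 nM (range 700 nM to 10000 nM), which means a step of a 1.6-fold lower number from compound 3 to compound 4 (0.20 log units; within the scatter).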

Compound 4, half-maximal effective concentration: 1090 nM
Estimate against measurement, compound 4: 2.6-fold (0.41 log units) above, within the range that was stated.
By their numbers in this assay, from the lowest: compound 1; then compound 2; then compound 4; then compound 3.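

In this assay, moving the methyl within the pyridine ether is itself a change beyond the scatter (a 4.1-fold lower number from compound 3 to compound 4 (0.61 log units; beyond the scatter)), so the place of the methyl on the pyridine counts, not only the presence of the pyridine ring. The 3-methylpyridin-2-yl group still does not reach the two phenyl ethers, leaving one gap to the 3-chlorophenyl ether (a 3.4-fold higher number from compound 2 to compound 4 (0.53 log units; beyond the scatter)) and a wider one to the 2-methylphenyl ether (an 8.8-fold higher number from compound 1 to compound 4 (0.94 log units; beyond the scatter)). Nothing available explains why the two methyl placements differ.

The compounds shown leave open what plain pyridin-2-yl without any methyl would give, so it cannot be said whether either methyl placement raises or lowers the number relative to that ring. From the compounds shown here alone, a methoxy group or a chlorine in place of the methyl is equally open.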